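Adding a Benzyloxy Group to Compound 1

A few compounds are considered here, and "the series" means these few. Any claim that something is new, unique, unknown or untested is made for them only; others in the source may bear on it.

Compound 1 (`Cc1cc(O)c(C(=O)/C=C/c2ccc(F)cc2)c(-c2ccccc2)c1C(=O)/C=C/c1ccc(F)cc1`) is the reference point here. Among the measured compounds shown here, in a functional assay on HeLa cells (Homo sapiens) for cytotoxicity, read by MTT assay, with a stated time of 24 h (a lower number here means a stronger inhibitor, a higher number a weaker inhibitor), compound 1 gives 30000 nM, and this is the only numerical reading in the small set at hand. Compound 2 (`Cc1cc(O)c(C(=O)/C=C/c2cccc3ccccc23)c(-c2ccccc2)c1C(=O)/C=C/c1cccc2ccccc12`), a close relative with larger aromatic arms, is reported in this assay as "not active" (no number reported), so no number stands beside it, and nothing can be said about the size of any difference between compound 1 and compound 2.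

Compound 3 (`Cc1cc(O)c(C(=O)/C=C/c2ccc(F)cc2)c(-c2ccc(OCc3ccccc3)cc2)c1C(=O)/C=C/c1ccc(F)cc1`) keeps everything of compound 1 except one change: benzyloxy in place of hydrogen on an aromatic carbon. For the measured compounds named here, no pair of measured compounds shows what such an exchange does, so no measured step can guide the expectation. With only compound 1 at 30000 nM as an anchor, the expected step is small, a 1.5-fold lower number from compound 1 to compound 3 (0.18 log units; within the scatter), within or close to the usual scatter, with no clear direction beyond it. Compound 3 is therefore expected to reach about 20000 nM in this assay, with a plausible range from 5000 nM to 60000 nM.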

Compound 3, half-maximal inhibitory concentration: 25000 nM
Estimate against measurement, compound 3: 1.3-fold (0.10 log units) below; the measured number falls inside the stated range.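

In this assay, placing benzyloxy in place of hydrogen on an aromatic carbon, para to a large group, gives a 1.2-fold lower number from compound 1 to compound 3 (0.08 log units; within the scatter), so compound 1 and compound 3 cannot be told apart in this test. Among the compounds shown here, this is the first measured look at this position, which the earlier compounds left untouched: the ring that carries it can take a group of 8 heavy atoms, including a further six-membered aromatic ring of carbon only, with no reading outside the ordinary spread of repeated measurements. No measurement on hand offers an explanation for this result, and the reading alone cannot say whether the added group has any influence on the cells or simply goes unnoticed.

On these data alone, a single pair supports no general rule about this position, and it remains open whether a small methoxy group, an amine or a carboxylic acid on the same carbon would also leave the reading in place. As far as these compounds go, it is equally open whether benzyloxy would give a similar result on another carbon of this ring, or whether changes elsewhere on the core of compound 1 matter more.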